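This account rests on a few compounds, and the source may have more. Where it says the series, first, only, none or still open, it means among the compounds named here.

In an ADME assay on S9 fraction from liver (Rattus norvegicus) for metabolic stability, with a stated time of 60 min (on this read-out higher numbers stand for a more stable compound and lower numbers for a less stable compound), compound 1 `Cc1nc(-c2nc[nH]n2)ccc1-c1cnc2c(n1)N(CC1CCOCC1)C(=O)CN2` gives 100%, compound 2 `Cc1nc(-c2nc[nH]n2)ccc1-c1cnc2c(n1)N(C(C)C)C(=O)CN2` gives 100% and compound 3 `COCCN1C(=O)CNc2ncc(-c3ccc(-c4nc[nH]n4)nc3C)nc21` gives 91%, so compound 3 stands within the scatter of both others. Compound 4 `CO[C@H]1CC[C@H](N2C(=O)CNc3ncc(-c4ccc(-c5nc[nH]n5)nc4C)nc32)CC1` differs from compound 3 at the amide-type nitrogen in a ring, where 4-methoxycyclohexyl replaces 2-methoxyethyl: 4-methoxycyclohexyl in place of 2-methoxyethyl on an amide-type nitrogen in a ring. Three measured steps alter the group on that nitrogen: no change at the digits printed from compound 1 to compound 2 (within the scatter), a number 9 percentage points lower from compound 1 to compound 3 (within the scatter) and a number 9 percentage points lower from compound 2 to compound 3 (within the scatter). For the measured compounds named here, none goes beyond the scatter, although no measured compound carries the 4-methoxycyclohexyl group. The expected result in this assay is therefore a number 1 percentage points lower from compound 3 to compound 4 (within the scatter), with no change beyond the scatter. For compound 4 the estimated value is 90%, with an expected range of 72% to 100%.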

Compound 4, percent of the compound remaining: 72%
The estimate for compound 4 lay 18 percentage points above the measured number; the measured number falls inside the stated range.
By their numbers in this assay, from the lowest: compound 4; then compounds 3, 1 and 2 (each within the scatter of the next).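

In this assay, the group on the amide-type nitrogen in a ring turns out to matter beyond the scatter, which no earlier change there showed: 4-methoxycyclohexyl gives a number 19 percentage points lower from compound 3 to compound 4 (beyond the scatter) and a number 28 percentage points lower from compound 2 to compound 4 (beyond the scatter) and a number 28 percentage points lower from compound 1 to compound 4 (beyond the scatter) in this series. Against 2-methoxyethyl, the number of hydrogen-bond acceptors stays the same, while a ring of carbon only and two defined stereocentres enter. Nothing measured here accounts for the drop. The compounds shown leave open whether the drop goes with the carbon ring or with its methoxy group, and how a plain cyclohexyl or a 4-hydroxycyclohexyl on that nitrogen would read.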